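The source may hold more compounds than are shown below. What is called first, only, known or untested is meant among the compounds shown, and "the series" means these compounds.

Three compounds that share one core and differ only in the chain on the amide carbonyl set the scene. In a functional assay on HT-29 cells (Homo sapiens) for antiproliferative activity, read by sulforhodamine B assay, with a stated time of 72 h (a higher number here means a weaker inhibitor, a lower number a stronger inhibitor), compound 1 `CCCCCCCCc1ccc(CCC(CO)(CO)NC(C)=O)c2ccccc12` gives 36500 nM, and compound 2 `CCCCCCCCc1ccc(CCC(CO)(CO)NC(=O)CCCCCCC)c2ccccc12` gives 22000 nM. Placing hexyl on that chain gives a 1.7-fold lower number from compound 1 to compound 2 (0.22 log units; within the scatter), so these two compounds cannot be told apart.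

Compound 3 `CCCCCCCCCC(=O)NC(CO)(CO)CCc1ccc(CCCCCCCC)c2ccccc12` reaches only a limit of the assay, > 80000 nM, and not a true number.

Even so, its steps are informative. Octyl in place of hydrogen gives an at least 2.1-fold higher number from compound 1 to compound 3 (0.34 log units; beyond the scatter), and the added ethyl gives an at least 3.6-fold higher number from compound 2 to compound 3 (0.56 log units; beyond the scatter). Both point towards weaker inhibition, although compound 2 goes against any steady trend with chain length.

Compound 4 `CCCCCCCCCCCCCC(=O)NC(CO)(CO)CCc1ccc(CCCCCCCC)c2ccccc12` extends the same chain again, with the change butyl in place of hydrogen on a saturated chain carbon, nine bonds along the chain from a carbonyl carbon.

The two steps into compound 3 are the closest guide, so a higher number is expected in this assay, and another limit is quite likely. The expected step is a step that the limit leaves unreadable from compound 3 to compound 4, and its size is loose since its starting point is only a limit. For compound 4 the estimated value is 120000 nM, with an expected range of 60000 nM to 250000 nM.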

Compound 4, half-maximal inhibitory concentration: > 80000 nM
Compound 4 ended at the assay's limit; the forecaster's own chance of this, stated with the estimate: 80%; the middle value does not contradict the limit.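

Compound 4, like compound 3, stops at a limit of the assay and not at a true number, so the butyl step between them cannot be read: the limit of > 80000 nM in this assay, at which 2 of the 4 values shown sit.

The other two steps can be read, at least as minimum sizes. In this assay, extending the chain on the amide carbonyl gives an at least 3.6-fold higher number from compound 2 to compound 4 (0.56 log units; beyond the scatter), and extending it from the shortest chain shown gives an at least 2.1-fold higher number from compound 1 to compound 4 (0.34 log units; beyond the scatter). The new result therefore shows that making the chain of compound 3 longer still does not bring a measurable value back, so the two longest chains shown both stay on the weak side of compound 1 and compound 2.

On these data alone, the order of compound 3 and compound 4 stays open, and so does the true size of every step that ends at compound 4. Also open, as far as these compounds go, is whether an amine or a carboxylic acid on this amide chain, in place of a plain alkyl chain, would lower the number in this assay.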